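The compounds below may be only part of what the source reports. "The series", "measured", "known", "first", "only" and "open" are said of these compounds alone.

Compound 1 `Cc1ccc(C(=O)N/N=C/c2ccccc2)c(O)c1` gives 53900 nM in a functional assay (Mus musculus, strain BALB/C) for inhibition, read by MTT assay, with stated times of 24 h and 72 h (a lower number here means a stronger inhibitor, a higher number a weaker inhibitor), the highest of the two numbers measured, and compound 2 `COc1cccc(/C=N/NC(=O)c2ccc(C)cc2O)c1` gives 20600 nM in this assay. Going by the values given here, the single measured step, a 2.6-fold lower number from compound 1 to compound 2 (0.42 log units; beyond the scatter), concerns a methoxy rather than a chloro, so it bears only loosely on compound 3 `Cc1ccc(C(=O)N/N=C/c2ccc(Cl)cc2)c(O)c1`, which differs from compound 1 by chloro in place of hydrogen on an aromatic carbon. Given that methoxy step, a similar modest move toward a lower number is expected for compound 3, a 1.6-fold lower number from compound 1 to compound 3 (0.21 log units; within the scatter), though one within the scatter would not surprise. The estimate for compound 3 is 33000 nM, with a range of 12000 nM to 90000 nM.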

Compound 3, half-maximal inhibitory concentration: 12300 nM
Estimate against measurement, compound 3: 2.7-fold (0.43 log units) above; measured number inside the range.
By their numbers in this assay, from the lowest: compounds 3 and 2 (each within the scatter of the next); then compound 1.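

In this assay chloro in place of hydrogen on an aromatic carbon, para to a large group, gives a 4.4-fold lower number from compound 1 to compound 3 (0.64 log units; beyond the scatter) and thus a modest gain beyond the scatter. With the earlier methoxy step, this makes a second substituent on this ring that lowers the number relative to compound 1, and here a single chlorine atom is enough. No available evidence accounts for this step. Going by these compounds, whether an amine or a carboxylic acid at this same place would also lower the number remains open. So does the effect of bromo there.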